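Methylamino in place of 1-hydroxyethyl on the shared core

The source may hold more compounds than are shown below. What is called first, only, known or untested is meant among the compounds shown, and "the series" means these compounds.

In a functional assay on cells (Homo sapiens), read by thymidine incorporation (a lower number here means a stronger inhibitor, a higher number a weaker inhibitor), compound 1 (`CCc1cc(NCc2cccnc2)n2ncc(Br)c2n1`) gives 520 nM and compound 2 (`CC(O)c1cc(NCc2cccnc2)n2ncc(Br)c2n1`) gives 1400 nM as the higher of the two numbers. Compound 3 (`CNc1cc(NCc2cccnc2)n2ncc(Br)c2n1`) carries methylamino in place of 1-hydroxyethyl on an aromatic carbon. Going by the values given here, one measured step bears on this, hydroxy in place of hydrogen on the chain that leaves here, and it is modest (a 2.7-fold higher number from compound 1 to compound 2 (0.43 log units; beyond the scatter)). Among the compounds with values here, no measured step covers methylamino itself. A modest step toward a lower number is therefore expected in this assay (a 2.3-fold lower number from compound 2 to compound 3 (0.37 log units; beyond the scatter)). For compound 3 the estimated value is 600 nM with an expected range of 200 nM to 1800 nM in this series.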

Compound 3, half-maximal inhibitory concentration: 1200 nM
Compound 3: middle estimate off by 2.0-fold (0.30 log units), on the low side; the measured number falls inside the stated range.
By their numbers in this assay, from the lowest: compound 1; then compounds 3 and 2 (each within the scatter of the next).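

In this assay, methylamino and 1-hydroxyethyl on this aromatic carbon cannot be told apart (a 1.2-fold lower number from compound 2 to compound 3 (0.07 log units; within the scatter)). Ethyl remains the group with the lowest number at this position, since methylamino also falls short of it (a 2.3-fold higher number from compound 1 to compound 3 (0.36 log units; beyond the scatter)), as 1-hydroxyethyl did. No measurement on hand explains this.

On these data alone, whether a longer chain such as propyl, or methoxy or dimethylamino, would match ethyl here stays open. The compounds shown also vary only this one position, so the bromine and the pyridinylmethylamino side of the shared core remain untested.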